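Swapping a methyl for a phenyl on a ring nitrogen

A few compounds are considered here, and "the series" means these few. Any claim that something is new, unique, unknown or untested is made for them only; others in the source may bear on it.

Measured so far in an assay for inhibition of sodium-dependent dopamine transporter (Rattus norvegicus); on this read-out lower numbers stand for stronger inhibition and higher numbers for weaker inhibition:
- Compound 1 `CN1C[C@@H](C(=O)c2ccccc2Cl)[C@H](c2ccc(Cl)cc2)C1` gives 610 nM.
- Compound 2 `CN1C[C@@H](C(=O)c2ccccn2)[C@H](c2ccccc2)C1` gives 630 nM.
- Compound 3 `CN1C[C@@H](C(=O)c2ccc(Cl)cc2)[C@H](c2ccc(Cl)cc2Cl)C1` gives 1260 nM.

Compound 2 sits second highest among these three numbers. Its nearest neighbour is compound 1, and the gap between the two is within the scatter; compound 3 is furthest away, yet that gap also stays within the scatter. On this evidence the three compounds cannot be told apart in this assay.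

Compound 4 `O=C(c1ccccn1)[C@@H]1CN(c2ccccc2)C[C@H]1c1ccccc1` has not been measured. It differs from compound 2 in one place: phenyl in place of methyl on an amine nitrogen in a ring. Among the compounds with values here, no step between two measured compounds matches this change, so there is nothing here to calibrate it against. The expectation is nonetheless a step beyond the scatter towards higher numbers, that is weaker inhibition, with the size of the expected step from compound 2 to compound 4 being a 6.3-fold higher number from compound 2 to compound 4 (0.80 log units; beyond the scatter). Compound 4 is accordingly estimated at 4000 nM in this assay, within a range from 1000 nM to 20000 nM.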

Compound 4, inhibition constant: > 10000 nM
Compound 4 was reported as a limit (the forecaster's own chance of this, stated with the estimate: 15%); middle value at least 2.5-fold (0.39 log units) from the limit.
By their numbers in this assay, from the lowest: compounds 1, 2 and 3 (each within the scatter of the next, the first and the last beyond it). At a limit, above all of these: compound 4.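

The ring nitrogen does not accept every group in this assay: phenyl in place of methyl on this amine nitrogen gives an at least 15-fold higher number from compound 2 to compound 4 (1.20 log units; beyond the scatter). Within the data shown here, this is the only step here between compounds that differ in one place, and it shows that this single position can, with the rest of compound 2 unchanged, carry the read-out beyond the range of the three earlier compounds. Compound 4 gives a limit and not a number, so the step has a lower bound but no known size: the limit of > 10000 nM in this assay, at which 1 of the 4 values shown sits.

An ethyl group, a benzyl group or a plain hydrogen on this nitrogen would show whether the drop is specific to phenyl or comes with any group larger than methyl. From the compounds shown here alone, whether the same swap would act alike on compound 1 or compound 3 also remains open.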